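Isobutoxy for propoxy on the cyclohexanetrione series

This account rests on a few compounds, and the source may have more. Where it says the series, first, only, none or still open, it means among the compounds named here.

Of the compounds shown here, two have been measured in a functional assay on HepG2 cells (Homo sapiens) for antiproliferative activity, read by sulforhodamine B assay, with a stated time of 3 days; on this read-out higher numbers stand for an effect only at larger amounts of compound and lower numbers for an effect already at smaller amounts. Compound 1 `CCCOC1=C(CCC)C(=O)/C(=C(O)/C=C/c2ccccc2)C(=O)C1(CCC)CCC` gives 8.3 uM in this assay. Compound 2 `CCCC1(CC=C(C)C)C(=O)C(C(=O)/C=C/c2ccccc2)=C(O)C(CCC)(CCC)C1=O`, which carries a prenyl chain in place of one propyl on the shared core, gives 6.4 uM in this assay. The two numbers fall within the usual scatter of each other, so compound 1 cannot be placed above or below compound 2; both sit in the same low-micromolar band and neither is called the more potent.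

Compound 3 `CCCC1=C(OCC(C)C)C(CCC)(CCC)C(=O)/C(=C(O)\C=C\c2ccccc2)C1=O` differs from compound 1 by one change: methyl in place of hydrogen on a saturated chain carbon bound to two saturated chain carbons. Within the data shown here, no single-point step between measured compounds is available to calibrate this change, and the one comparison in hand, compound 1 against compound 2, itself stays within the scatter. The change adds a single carbon to a side chain and leaves the core untouched, so no shift beyond the scatter is expected for compound 3 in this assay; a step of a 1.0-fold lower number from compound 1 to compound 3 (0.02 log units; within the scatter) is the estimate. Compound 3 is therefore expected to give about 8 uM in this assay, with a range of 3.5 uM to 20 uM.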

Compound 3, concentration for half-maximal effect: 13.4 uM
Compound 3: the middle estimate sits 1.7-fold (0.22 log units) below what was measured; measured number inside the range.
By their numbers in this assay, from the lowest: compounds 2, 1 and 3 (each within the scatter of the next, the first and the last beyond it).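

Among these compounds, this is the first step that can be read as one change on the shared core: in this assay, isobutoxy for propoxy, a methyl in place of hydrogen on a saturated chain carbon bound to two saturated chain carbons, gives a 1.6-fold higher number from compound 1 to compound 3 (0.21 log units; within the scatter). The earlier comparison of compound 1 and compound 2 could not speak to this place, whereas this step shows that propoxy and isobutoxy cannot be told apart here, so branching this chain by one methyl is tolerated in this read-out. No measurement in hand bears on the reason for this outcome.

This one step says nothing about how far the chain at this place can be altered: a longer chain such as hexyloxy, a benzyloxy group or an aminoethoxy group could still move the number beyond the scatter, or stay within it. It also leaves open whether the same exchange of ethyl for isopropyl or propyl for isobutyl elsewhere on the shared core would behave in the same way in this assay, since only this one place has a step.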